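From a Methoxypropoxy Chain to an Isopentyloxy Chain

A few compounds are considered here, and "the series" means these few. Any claim that something is new, unique, unknown or untested is made for them only; others in the source may bear on it.

The measured compounds:
compound 1, `CCCCOc1ccc(C(CC(=O)O)c2ccccc2)cc1`, in a functional assay on HEK293 cells for agonist activity at Free fatty acid receptor 1 (Homo sapiens), read by calcium flux (on this read-out higher numbers stand for an effect only at larger amounts of compound and lower numbers for an effect already at smaller amounts), gives 1.2 uM
compound 2, `CCCCCCCOc1ccc(C(CC(=O)O)c2ccccc2)cc1`, in this assay gives 4.26 uM
compound 3, `COCCCOc1ccc(C(CC(=O)O)c2ccccc2)cc1`, in this assay gives 7.58 uM

Compound 3 has the highest of the three numbers. Its distance from compound 2 is within the scatter, while the step of a 6.3-fold higher number from compound 1 to compound 3 (0.80 log units; beyond the scatter) lies beyond it. Compound 4, `CC(C)CCOc1ccc(C(CC(=O)O)c2ccccc2)cc1`, differs from compound 3 in one place: isopropyl in place of methoxymethyl on a saturated chain carbon, two bonds along the chain from an oxygen on an aromatic ring.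

For the measured compounds named here, two measured steps bear on this change. The step of a 6.3-fold higher number from compound 1 to compound 3 (0.80 log units; beyond the scatter) shows that an oxygen placed in the chain raised the number, and the step of a 3.6-fold higher number from compound 1 to compound 2 (0.55 log units; beyond the scatter) shows that lengthening the all-carbon chain raised it by less. Compound 4 carries an all-carbon chain, one carbon longer than that of compound 1 and branched, and so is expected to sit nearer compound 1 than compound 3. Compound 4 is therefore estimated at 2 uM, within a range of 0.8 uM to 5 uM. The step this estimate implies is a 3.8-fold lower number from compound 3 to compound 4 (0.58 log units; beyond the scatter).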

Compound 4, concentration for half-maximal effect: 1.86 uM
The estimate for compound 4 lay 1.1-fold (0.03 log units) above the measured number, and the stated range covers the measured number.
By their numbers in this assay, from the lowest: compounds 1 and 4 (each within the scatter of the next); then compounds 2 and 3 (each within the scatter of the next).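

In this assay, isopropyl in place of methoxymethyl gives a 4.1-fold lower number from compound 3 to compound 4 (0.61 log units; beyond the scatter), so exchanging the chain oxygen for carbon, with the heavy-atom count unchanged, moves the number beyond the scatter. Isopropyl in place of pentyl at the same place gives a 2.3-fold lower number from compound 2 to compound 4 (0.36 log units; beyond the scatter), whereas methyl in place of hydrogen on a saturated chain carbon bound to two saturated chain carbons gives a 1.6-fold higher number from compound 1 to compound 4 (0.19 log units; within the scatter), so this branching step cannot be told from the scatter. Nothing available explains these steps.

The compounds shown leave open whether the step from methoxymethyl to isopropyl would hold if the oxygen stood elsewhere in the chain. They also leave open how a chain ending in a cyclopropyl ring, a trifluoromethyl group or an amine would compare.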